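This account rests on a few compounds, and the source may have more. Where it says the series, first, only, none or still open, it means among the compounds named here.

Compound 2 `C#Cc1ccn2cc(-c3ccc(NC(=O)Nc4cc(C(C)(C)C)on4)cc3)nc2c1` gives 4110 ug/mL in a physicochemical assay for solubility (a lower number here means a less soluble compound, a higher number a more soluble compound), a number within the scatter of compound 1 `CC(C)(C)c1cc(NC(=O)Nc2ccc(-c3cn4ccccc4n3)cc2)no1`, which gives 4070 ug/mL. Among the measured compounds shown here, only one measured step bears on the change in hand, a 1.0-fold higher number from compound 1 to compound 2 (0.00 log units; within the scatter), and it lies within the scatter. The change to compound 3 `COc1ccn2cc(-c3ccc(NC(=O)Nc4cc(C(C)(C)C)on4)cc3)nc2c1` is methoxy in place of ethynyl on an aromatic carbon, at the same place as that step. With no measured step beyond the scatter to build on, compound 3 is expected to stay close to compound 2, and the estimated step from compound 2 to compound 3 is a 1.0-fold lower number from compound 2 to compound 3 (0.01 log units; within the scatter). Compound 3 is therefore estimated at 4000 ug/mL, with a range from 2000 ug/mL to 8000 ug/mL.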

Compound 3, solubility: 3150 ug/mL
Beside the measured number, compound 3's estimate is 1.3-fold (0.10 log units) above it; the measured number falls inside the stated range.
By their numbers in this assay, from the lowest: compounds 3, 1 and 2 (each within the scatter of the next).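

In this assay, methoxy on the aromatic carbon opposite the ring nitrogen gives a second substituent at this position, and it too stays within the scatter, both against ethynyl (a 1.3-fold lower number from compound 2 to compound 3 (0.12 log units; within the scatter)) and against hydrogen (a 1.3-fold lower number from compound 1 to compound 3 (0.11 log units; within the scatter)). Hydrogen, ethynyl and methoxy therefore cannot be told apart here, although methoxy brings a hydrogen-bond acceptor that ethynyl lacks. Nothing measured here gives a reason for these small steps. The compounds shown leave open whether an amine, a carboxylic acid or a longer chain at this position would produce a step beyond the scatter.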